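Amide to Urea Change on a Weak Growth Inhibitor

This account rests on a few compounds, and the source may have more. Where it says the series, first, only, none or still open, it means among the compounds named here.

Measured compounds:
compound 1, `COc1cc(-c2nn(-c3cccc(NC(=O)c4cccc(C(F)(F)F)c4)c3)cc2-c2ccncc2)ccc1Cl`, 1130 nM
compound 2, `COc1cc(-c2nn(-c3cccc(NC(=O)Nc4ccc(Cl)c(Cl)c4)c3)cc2-c2ccncc2)ccc1Cl`, 1050 nM
compound 3, `COc1cc(-c2nn(-c3cccc(NC(=O)c4ccc(Cl)c(C(F)(F)F)c4)c3)cc2-c2ccncc2)ccc1Cl`, 2190 nM

All three were tested in a functional assay on SNB-75 cells (Homo sapiens) for inhibition, read by sulforhodamine B assay, with a stated time of 48 h; a lower number here means a stronger inhibitor of growth, a higher number a weaker inhibitor of growth. Compound 3 gives the highest number of the three: compound 1 stands a 1.9-fold higher number from compound 1 to compound 3 (0.29 log units; within the scatter), a gap within the scatter, while compound 2 stands a 2.1-fold higher number from compound 2 to compound 3 (0.32 log units; beyond the scatter), a modest gap beyond it.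

Compound 4, `COc1cc(-c2nn(-c3cccc(NC(=O)Nc4ccc(Cl)c(C(F)(F)F)c4)c3)cc2-c2ccncc2)ccc1Cl`, has not yet been measured. It differs from compound 3 by (4-chloro-3-(trifluoromethyl)phenyl)amino in place of 4-chloro-3-(trifluoromethyl)phenyl on a carbonyl carbon, so the amide becomes a urea while the aryl group stays the same.

Two measured steps speak to this. The change from an amide to a urea, combined with a change of aryl group, gave a 1.1-fold lower number from compound 1 to compound 2 (0.03 log units; within the scatter). The comparison of the urea of compound 2 with the amide of compound 3 gave a 2.1-fold higher number from compound 2 to compound 3 (0.32 log units; beyond the scatter). Neither step isolates the amide-to-urea change alone, but both point to the urea giving a similar or somewhat lower number.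

For compound 4 the estimate is therefore a 1.6-fold lower number from compound 3 to compound 4 (0.19 log units; within the scatter), a small expected shift toward a lower number. The expected value for compound 4 is 1400 nM, with a range from 600 nM to 3200 nM.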

Compound 4, concentration for 50% growth inhibition: 1280 nM
The estimate for compound 4 lay 1.1-fold (0.04 log units) above the measured number, within the range that was stated.
By their numbers in this assay, from the lowest: compounds 2, 1, 4 and 3 (each within the scatter of the next, the first and the last beyond it).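

Going by these compounds alone, compound 3 and compound 4 carry the same 4-chloro-3-(trifluoromethyl)phenyl, so this is the first pair in which an amide becomes a urea with nothing else changed, and in this assay this gives a 1.7-fold lower number from compound 3 to compound 4 (0.23 log units; within the scatter). Within the ureas, trifluoromethyl in place of chloro on an aromatic carbon gives a 1.2-fold higher number from compound 2 to compound 4 (0.09 log units; within the scatter), while the remaining pair, which adds a chloro as well as the amino, gives a 1.1-fold higher number from compound 1 to compound 4 (0.05 log units; within the scatter). None of these three changes clearly separates the compounds, and nothing further is available to explain these numbers.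

On these data alone, whether the urea and amide also match with another aryl group remains open, as compound 2 has no amide partner bearing 3,4-dichlorophenyl. As far as these compounds go, the effect of a morpholine or a carboxylic acid in place of the aryl group on the carbonyl carbon also remains open.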